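The compounds below may be only part of what the source reports. "The series", "measured", "known", "first", "only" and "open" are said of these compounds alone.

In an ADME assay (liver) for metabolic stability, with Liver microsome (Homo sapiens) as the target, read by LC-MS, using microsomes and NADPH, with a stated time of 5 min, at 37 degrees C (on this read-out lower numbers stand for slow clearance and higher numbers for fast clearance), compound 3 (`CCn1c([C@@H](C)NS(=O)(=O)c2cccc(C#N)c2)nc2ccc(C(F)(F)F)cc21`) gives only a limit, > 100 mL.min-1.g-1. Compound 2 (`CCn1c([C@@H](C)NS(=O)(=O)c2ccc(C)cc2)nc2ccc(C(F)(F)F)cc21`) also gives a limit, > 100 mL.min-1.g-1. Compound 1 (`CCn1c([C@@H](C)NS(=O)(=O)C2CC2)nc2ccc(C(F)(F)F)cc21`) gives a limit too, < 3 mL.min-1.g-1. Compound 4 (`CCn1c([C@@H](C)NS(=O)(=O)c2ccc(CC(C)C)cc2)nc2ccc(C(F)(F)F)cc21`) differs from compound 3 through (4-isobutylphenyl in place of 3-cyanophenyl on a sulfonyl sulfur), with 4-isobutylphenyl in place of 3-cyanophenyl on a sulfonyl sulfur. The measured steps that bear on this change are an at least 33-fold higher number from compound 1 to compound 2 (1.52 log units; beyond the scatter) and an at least 33-fold higher number from compound 1 to compound 3 (1.52 log units; beyond the scatter), both large, together with a step that the two limits leave unreadable from compound 2 to compound 3. Compound 4 keeps a phenyl ring on the sulfonyl sulfur, as compound 2 and compound 3 do, so no step beyond the scatter is expected in this assay, and another limit is likely. The estimated step is a step that the limit leaves unreadable from compound 3 to compound 4. For compound 4 the expected value is 150 mL.min-1.g-1, with an estimated range from 70 mL.min-1.g-1 to 300 mL.min-1.g-1.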

Compound 4, intrinsic clearance in microsomes: > 100 mL.min-1.g-1
Compound 4 ended at the assay's limit (the forecaster's own chance of this, stated with the estimate: 85%); the middle value lies beyond the limit too.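

In this assay, 4-isobutylphenyl in place of cyclopropyl on the sulfonyl sulfur gives an at least 33-fold higher number from compound 1 to compound 4 (1.52 log units; beyond the scatter). Compound 4 therefore extends the contrast with compound 1 to a third substituted phenyl ring, one that carries neither the methyl of compound 2 nor the nitrile of compound 3. The steps among compound 2, compound 3 and compound 4 cannot be read, as all three values are limits: the limit of > 100 mL.min-1.g-1 in this assay, at which 3 of the 4 values shown sit.

On these data alone, how these three rank remains open. So does whether a phenyl ring bearing an amine or a carboxylic acid, or a longer chain on the sulfur, would stay close to compound 1.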